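Moving a bromine around the amide ring of compound 1

The source may report more compounds than this note shows. Statements on the series, on what has been measured and on what is new or still open speak of the compounds shown alone.

Compounds measured so far, each with its number in a functional assay on SK-BR-3 cells (Homo sapiens) for antiproliferative activity, read by MTT assay, with a stated time of 72 h; on this read-out lower numbers stand for stronger inhibition and higher numbers for weaker inhibition:
- compound 1, `CCN1CCN(c2cc(C)c3cc(NC(=O)c4ccc(Br)cc4)ccc3n2)CC1`: 6310 nM
- compound 2, `Cc1cc(N2CCCCC2)nc2ccc(NC(=O)c3ccc(Cl)c(Cl)c3)cc12`: 42500 nM
- compound 3, `Cc1cc(NCCN2CCCCC2)nc2ccc(NC(=O)c3ccc(Cl)c(Cl)c3)cc12`: 1800 nM

Compound 1 holds the second highest number of the three. Compound 3 sits lower than compound 1, and compound 2 sits higher; both of those gaps lie beyond the usual scatter, so compound 1 is neither the strongest nor the weakest inhibitor here.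

Compound 4, `CCN1CCN(c2cc(C)c3cc(NC(=O)c4cccc(Br)c4)ccc3n2)CC1`, differs from compound 1 in one place: 3-bromophenyl in place of 4-bromophenyl on a carbonyl carbon. Going by the values given here, the only step measured so far is a 24-fold lower number from compound 2 to compound 3 (1.37 log units; beyond the scatter), and that step alters the amine-bearing side of the shared core, not the bromophenyl attached to the carbonyl carbon. Among the compounds with values here, no measured step therefore bears on the change from compound 1 to compound 4, and nothing among the three compounds shows how this assay responds to shifting the bromine within that ring.

With no guidance either way, the expectation is a step of no size beyond the scatter, a 1.0-fold lower number from compound 1 to compound 4 (0.00 log units; within the scatter). Compound 4 is accordingly estimated at 6300 nM, with a range from 2000 nM to 20000 nM that allows for a moderate shift in either direction.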

Compound 4, half-maximal inhibitory concentration: 13300 nM
Compound 4: middle estimate off by 2.1-fold (0.32 log units), on the low side; the range from low to high includes it.
By their numbers in this assay, from the lowest: compound 3; then compound 1; then compound 4; then compound 2.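

Shifting the bromine, with 3-bromophenyl in place of 4-bromophenyl on the carbonyl carbon, gives in this assay a 2.1-fold higher number from compound 1 to compound 4 (0.32 log units; beyond the scatter), a modest step but one beyond the usual scatter. Going by these compounds alone, this is the first measured change in the ring on the carbonyl carbon, as the earlier step between compound 2 and compound 3 concerned only the amine-bearing side of the shared core, and it shows that this position does register in the read-out: both groups have the same atoms and the same counts of donors and acceptors, so the two compounds differ only in how those atoms are joined. No measured property of the two compounds is available to explain the difference.

From the compounds shown here alone, it remains open whether the same shift of the bromine would give a similar step on a core carrying the (2-(piperidin-1-yl)ethyl)amino group of compound 3, which holds the lowest number so far. The compounds shown also leave open what a methoxy group, a nitrile or a carboxylic acid would do in place of the bromine on this ring.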